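Chlorine position on the benzyl group of the shared core

The source may report more compounds than this note shows. Statements on the series, on what has been measured and on what is new or still open speak of the compounds shown alone.

Measured so far:
compound 1, `CC(C)(C)c1ccc(CN2C(=O)S/C(=C\c3ccc(N)cc3)C2=O)cc1`: 94000 nM
compound 2, `Nc1ccc(/C=C2\SC(=O)N(Cc3cccc(Cl)c3)C2=O)cc1`: 4700 nM

Among the measured compounds shown here, in a functional assay on L1210 cells (Mus musculus) for cytotoxicity, read by cell counting, with a stated time of 2 days (on this read-out higher numbers stand for weaker inhibition and lower numbers for stronger inhibition), compound 2 gives 4700 nM, the lowest number of the two measured compounds; the only neighbour is compound 1, whose number is higher by a gap that lies beyond the scatter. Compound 1 carries a tert-butyl group on its benzyl ring where compound 2 carries nothing, and its chlorine-free ring is the weaker of the two in this assay.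

Compound 3, `Nc1ccc(/C=C2\SC(=O)N(Cc3ccc(Cl)cc3)C2=O)cc1`, is the next step from compound 2. The change is 4-chlorophenyl in place of 3-chlorophenyl on a saturated chain carbon bound to an amide-type nitrogen in a ring. For the measured compounds named here, no measured pair shows the same move of a chlorine, so the size of the step is not anchored by data. Given that compound 1, with its bulkier group in the 4-position, gives 94000 nM, a modest rise in the number from compound 2 to compound 3 is expected, of a size that may not clear the scatter: a 1.7-fold higher number from compound 2 to compound 3 (0.23 log units; within the scatter). For compound 3 the estimate in this assay is 8000 nM, with a range of 2500 nM to 30000 nM.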

Compound 3, half-maximal inhibitory concentration: 37000 nM
For compound 3 the middle estimate is 4.6-fold (0.67 log units) below the measured one; the measured number lies above the stated range.
By their numbers in this assay, from the lowest: compound 2; then compound 3; then compound 1.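

In this assay, relocating the chlorine is enough on its own to change the read-out: the step is a 7.9-fold higher number from compound 2 to compound 3 (0.90 log units; beyond the scatter), although 3-chlorophenyl and 4-chlorophenyl have the same atoms and the same counts, and the place on the saturated chain carbon bound to an amide-type nitrogen in a ring stays the same. This makes the position of the chlorine on the benzyl ring a variable in its own right for the shared core, which compounds 1 and 2 alone could not show, as they differ in both the group and its place. The exchange of tert-butyl for chloro on an aromatic carbon can now also be read as a single change, giving a 2.5-fold lower number from compound 1 to compound 3 (0.40 log units; beyond the scatter), and no measured property at hand accounts for either step.

Still open, going by these compounds, is whether a methoxy group, an amine or a carboxylic acid in place of the chlorine would follow compound 2 or compound 3. Also open, on these data alone, is whether the effect of the chlorine position would persist with a longer chain in place of the saturated chain carbon bound to the amide-type nitrogen.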